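The compounds below may be only part of what the source reports. "The series", "measured", "known", "first", "only" and "open" are said of these compounds alone.

Working notes on the series. In a physicochemical assay for lipophilicity, using the shake flask method, in phosphate buffer, measured as octanol-water partition, with a stated time of 30 min, at pH 7.4 (on this read-out higher numbers stand for higher lipophilicity and lower numbers for lower lipophilicity), compound 1 `Cc1nccn1-c1cnc(NCc2c(F)ccc3c2CCO3)c2cn[nH]c(=O)c12` gives 2.1. Compound 2 `C[C@@H]1CC(=O)N(c2cnc(NCc3c(F)ccc4c3CCO4)n3cnnc23)C1` gives 1.8, within the scatter of compound 1. Compound 3 `Cc1ncccc1-c1cnc(NCc2c(F)ccc3c2CCO3)c2n[nH]c(=O)n12` gives 2.5, beyond the scatter and higher than compound 1, so compound 1 sits level with compound 2 and under compound 3.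

Compound 4 `Cc1ncc(-c2cnc(NCc3c(F)ccc4c3CCO4)c3cn[nH]c(=O)c23)n1C` has no number yet in this assay. It differs from compound 1 in one place, on an aromatic carbon of the shared core, where 1,2-dimethyl-1H-imidazol-5-yl stands in place of 2-methyl-1H-imidazol-1-yl: 1,2-dimethyl-1H-imidazol-5-yl in place of 2-methyl-1H-imidazol-1-yl on an aromatic carbon.

Within the data shown here, no measured pair isolates a change of this kind, so the expectation starts from compound 1 at 2.1. A slight upward move, not beyond the scatter, is expected for the step of a number 0.10 log units higher from compound 1 to compound 4 (within the scatter). The estimated value for compound 4 is 2.2, with an expected range from 1.8 to 2.6.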

Compound 4, distribution coefficient: 1.9
Compound 4: the middle estimate sits 0.30 log units above what was measured; low and high end bracket the measured number.
By their numbers in this assay, from the lowest: compounds 2, 4 and 1 (each within the scatter of the next); then compound 3.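

In this assay, among these compounds, the single pair that isolates a change at this position gives a number 0.20 log units lower from compound 1 to compound 4 (within the scatter). On this aromatic carbon of the shared core, 1,2-dimethyl-1H-imidazol-5-yl and 2-methyl-1H-imidazol-1-yl therefore stand level, so this exchange between two five-membered aromatic rings with the same hetero atom count does not separate the two compounds on this read-out. Nothing measured on either group accounts for this step, and no supporting data bear on it.

A single pair cannot show whether the same exchange would also leave the read-out level on another core. It also leaves open how a group of a different kind, such as a primary amine, a carboxylic acid or a longer alkyl chain, would read at this position.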